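The source may hold more compounds than are shown below. What is called first, only, known or untested is meant among the compounds shown, and "the series" means these compounds.

Measured compounds in an ADME assay on HEK-293T cells (Homo sapiens) for cytotoxicity, read by MTT assay, with a stated time of 24 h; on this read-out higher numbers stand for lower toxicity in this test and lower numbers for higher toxicity in this test:
compound 1 `O=C(c1cccnc1)n1c(-c2cn(-c3ccccc3)nc2-c2ccc(F)cc2)nc2ccccc21`: 216000 nM
compound 2 `Cc1ccc(-c2nn(-c3ccccc3)cc2-c2nc3ccccc3n2C(=O)c2cncc(C)c2)cc1`: 155000 nM
compound 3 `Cc1cncc(C(=O)n2c(-c3cn(-c4ccccc4)nc3-c3ccc(C(F)(F)F)cc3)nc3ccccc32)c1`: 123000 nM

Compound 3 gives the lowest of the three numbers, yet its gaps to compound 2 and to compound 1 both lie within the scatter, so the three read as one level. Going by the values given here, the single step with one change, a 1.3-fold lower number from compound 2 to compound 3 (0.10 log units; within the scatter), is likewise within the scatter.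

Compound 4 `Cc1ccc(C(=O)n2c(-c3cn(-c4ccccc4)nc3-c3ccc(C(F)(F)F)cc3)nc3ccccc32)cc1` differs from compound 3 by 4-methylphenyl in place of 5-methylpyridin-3-yl on a carbonyl carbon. Among the compounds with values here, no measured step touches this change, and nothing among the three values speaks for movement in either direction. The expectation for compound 4 in this assay is therefore a step no larger than the scatter, a 1.1-fold lower number from compound 3 to compound 4 (0.05 log units; within the scatter). Compound 4 is estimated at 110000 nM, within 50000 nM to 250000 nM.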

Compound 4, half-maximal cytotoxic concentration: 169000 nM
Estimate against measurement, compound 4: 1.5-fold (0.19 log units) below; low and high end bracket the measured number.
By their numbers in this assay, from the lowest: compounds 3, 2, 4 and 1 (each within the scatter of the next).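

Replacing 5-methylpyridin-3-yl with 4-methylphenyl on a carbonyl carbon gives, in this assay, a 1.4-fold higher number from compound 3 to compound 4 (0.14 log units; within the scatter). This position therefore tolerates an all-carbon ring in place of a ring with one hetero atom, with the hydrogen-bond acceptor of that ring gone and the number still within the scatter. No measured information accounts for the size of this step.

Still open, as far as these compounds go, is whether an amine or a carboxylic acid on this ring, or a longer chain in its place on the carbonyl carbon, would take the number beyond the scatter.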